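Replacing 2,4-Difluorophenyl with 3-Nitrophenyl in Compound 3

This account rests on a few compounds, and the source may have more. Where it says the series, first, only, none or still open, it means among the compounds named here.

In an assay on isolated protein for inhibition of Amine oxidase [flavin-containing] B (Homo sapiens), read by fluorescence, with stated times of 15 min and 20 min (on this read-out higher numbers stand for weaker inhibition and lower numbers for stronger inhibition), compound 2 `CC(C)(C)c1cc(/C=C/C(=O)NCCC2CCN(Cc3ccc(F)cc3F)CC2)cc(C(C)(C)C)c1O` gives 12500 nM, and in this assay compound 1 `CC(C)(C)c1cc(/C=C/C(=O)NCCC2CCN(Cc3ccc(F)cc3)CC2)cc(C(C)(C)C)c1O` gives 11100 nM; the two numbers sit within the scatter of each other, as the step of a 1.1-fold higher number from compound 1 to compound 2 (0.05 log units; within the scatter) shows. Compound 3 `CC(C)(C)c1cc(/C=C/C(=O)NCCC2CCN(Cc3cccc([N+](=O)[O-])c3)CC2)cc(C(C)(C)C)c1O` carries 3-nitrophenyl in place of 2,4-difluorophenyl on a saturated chain carbon bound to an amine nitrogen in a ring. Going by the values given here, the one measured step concerns a fluoro in place of hydrogen, a different change, so it gives no direct guide here; with nothing pointing either way, no shift beyond the scatter in this assay is expected. Compound 3 is therefore estimated at 12000 nM, within 5000 nM to 30000 nM. The expected step is a 1.0-fold lower number from compound 2 to compound 3 (0.02 log units; within the scatter).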

Compound 3, half-maximal inhibitory concentration: 12500 nM
Compound 3: middle estimate off by 1.0-fold (0.02 log units), on the low side; the measured number falls inside the stated range.
By their numbers in this assay, from the lowest: compounds 1, 2 and 3 (each within the scatter of the next).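

In this assay, 3-nitrophenyl on a saturated chain carbon bound to an amine nitrogen in a ring reads the same as either fluorinated group, 2,4-difluorophenyl (no change at the digits printed from compound 2 to compound 3 (within the scatter)) and 4-fluorophenyl (a 1.1-fold higher number from compound 1 to compound 3 (0.05 log units; within the scatter)). The earlier step covered only a fluoro in place of hydrogen, whereas here the fluorines give way to a nitro group and the number still stays within the scatter. No evidence is available that would explain this result.

On these data alone, whether an amine or a carboxylic acid on this phenyl ring would move the number beyond the scatter stays open, as does the effect of a longer chain at this place.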